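From 2,5-Dimethylphenyl to 2,6-Dimethylphenyl on the Amide Nitrogen

A few compounds are considered here, and "the series" means these few. Any claim that something is new, unique, unknown or untested is made for them only; others in the source may bear on it.

In an ADME assay on HEp-2 cells (Homo sapiens) for cytotoxicity (a lower number here means that less compound is tolerated, a higher number that more compound is tolerated), compound 1 `O=C(Nc1ccccc1)[C@@H]1CCCN1S(=O)(=O)c1cccc2cccnc12` gives 35600 nM and compound 2 `Cc1ccc(C)c(NC(=O)[C@@H]2CCCN2S(=O)(=O)c2cccc3cccnc23)c1` gives 30900 nM so compound 2 stands within the scatter of compound 1. Compound 3 `Cc1cccc(C)c1NC(=O)[C@@H]1CCCN1S(=O)(=O)c1cccc2cccnc12` differs from compound 2 by 2,6-dimethylphenyl in place of 2,5-dimethylphenyl on an amide-type nitrogen which puts 2,6-dimethylphenyl in place of 2,5-dimethylphenyl on an amide-type nitrogen. Among the measured compounds shown here, the one measured step bearing on this is a 1.2-fold lower number from compound 1 to compound 2 (0.06 log units; within the scatter) and it involves the same nitrogen. Nothing measured points to a larger change, so the expected step is a 1.0-fold higher number from compound 2 to compound 3 (0.02 log units; within the scatter) in this assay with no shift beyond the scatter expected. Compound 3 is estimated at 32000 nM with an expected range from 16000 nM to 60000 nM in this measurement.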

Compound 3, half-maximal cytotoxic concentration: > 50000 nM
Compound 3: a limit, no number; the forecaster's own chance of this, stated with the estimate: 5%; at least 1.5-fold (0.19 log units) between middle value and limit.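

Among the compounds shown here, on the amide-type nitrogen, 2,6-dimethylphenyl in place of 2,5-dimethylphenyl is the first change here to end at a limit of this assay rather than a number, and compound 3 alone carries it: the limit of > 50000 nM in this assay, at which 1 of the 3 values shown sits. The steps read as an at least 1.6-fold higher number from compound 2 to compound 3 (0.20 log units; that floor lies within the scatter) and an at least 1.4-fold higher number from compound 1 to compound 3 (0.14 log units; that floor lies within the scatter). Both are floors, so neither shows a shift beyond the scatter, though the true gaps could be larger.

As far as these compounds go, how far compound 3 lies past its limit stays open. So does the outcome with a chlorine, a methoxy group or an amine on that phenyl.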